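This account rests on a few compounds, and the source may have more. Where it says the series, first, only, none or still open, it means among the compounds named here.

Compound 2 `O=C(c1ccc2c(c1)CCCC2)C1CCN(Cc2coc(-c3ccc(F)cc3)n2)CC1` was tested in an ADME assay on HEK293 cells (Homo sapiens) for cytotoxicity, read by MTT assay, with a stated time of 36 h; a lower number here means a stronger inhibitor, a higher number a weaker inhibitor. In this assay compound 2 reaches only a limit, > 150 ug/mL, so no number is known for it. Compound 1 `CC(C)(C)c1ccc(-c2nc(CN3CCC(C(=O)c4ccc5c(c4)OCCO5)CC3)co2)cc1` likewise reaches only a limit, > 150 ug/mL. Both values therefore sit at the limit of > 150 ug/mL in this assay, at which 2 of the 2 values shown sit, and nothing separates them. Compound 3 `CC(C)(C)c1ccc(-c2nc(CN3CCC(C(=O)c4ccc5c(c4)CCCC5)CC3)co2)cc1` differs from compound 2 by tert-butyl in place of fluoro on an aromatic carbon. Going by the values given here, with both known values at the limit, no measured step can guide the size of this change, and a step from compound 2 to compound 3 of a number no higher from compound 2 to compound 3 (the limit leaves the size open) is expected, none beyond the scatter. Compound 3 is estimated at 150 ug/mL, between 50 ug/mL and 300 ug/mL, most likely again reported only as a limit.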

Compound 3, half-maximal inhibitory concentration: > 150 ug/mL
Compound 3: no number, only a limit; the forecaster's own chance of this, stated with the estimate: 80%; the middle value lies on the limit itself.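

Compound 3, like compound 1 and compound 2, gives only a limit, so no step from compound 1 or compound 2 to compound 3 can be read: the limit of > 150 ug/mL in this assay, at which 3 of the 3 values shown sit.

From the compounds shown here alone, the actual value of each compound, and whether exchanging fluoro for tert-butyl changes it, stays open.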